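A few compounds are considered here, and "the series" means these few. Any claim that something is new, unique, unknown or untested is made for them only; others in the source may bear on it.

Compound 1 `N[C@H]1CC[C@H](Nc2c(C(=O)NCc3ccc(F)cc3)nc(N3CCCCC3)c3cccnc23)CC1`: > 10000 nM
Compound 2 `N[C@H]1CC[C@H](Nc2c(C(=O)NCc3ccc(Cl)cc3)nc(Br)c3cccnc23)CC1`: 2000 nM
Compound 3 `N[C@H]1CC[C@H](Nc2c(C(=O)NCc3ccc(Oc4ccccc4)cc3)nc(Br)c3cccnc23)CC1`: "not determined" (no result reported)

The study measures a functional assay on SK-BR-3 cells (Homo sapiens) for cytotoxicity, read by MTT assay, with a stated time of 72 h; on this read-out lower numbers stand for stronger inhibition and higher numbers for weaker inhibition. In this assay, among the measured compounds shown here, compound 2 gives 2000 nM, the only number reported among the three compounds. In this assay compound 1 gives > 10000 nM, a limit of the assay and not a number, which is the limit of > 10000 nM in this assay, at which 1 of the 3 values shown sits. For compound 3 the result is "not determined" (no result reported), so compound 2 stands alone as the single anchor for any expectation.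

Compound 4 `N[C@H]1CC[C@H](Nc2c(C(=O)NCc3ccco3)nc(Br)c3cccnc23)CC1` has not been measured. It differs from compound 2 in one place: furan-2-yl in place of 4-chlorophenyl on a saturated chain carbon bound to an amide-type nitrogen. For the measured compounds named here, no step between two measured compounds isolates this change, so its effect cannot be read from the data. The furan-2-yl group brings fewer heavy atoms and one hydrogen-bond acceptor where the 4-chlorophenyl group had none; which way this moves the read-out is not shown by any pair in the set. Compound 4 is therefore estimated, with wide uncertainty, to come out somewhat weaker than compound 2, a step of a 2.5-fold higher number from compound 2 to compound 4 (0.40 log units; beyond the scatter), giving an expected value of 5000 nM with a range from 1500 nM to 20000 nM.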

Compound 4, half-maximal inhibitory concentration: 10000 nM
The estimate for compound 4 lay 2.0-fold (0.30 log units) below the measured number, within the range that was stated.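

In this assay, among the compounds shown here, this is the first change at this place that can be read: furan-2-yl in place of 4-chlorophenyl on a saturated chain carbon bound to an amide-type nitrogen gives a 5.0-fold higher number from compound 2 to compound 4 (0.70 log units; beyond the scatter). The position therefore responds to the group it carries, and the smaller ring with one hydrogen-bond acceptor goes with the weaker result, although this single pair cannot separate the loss of chlorine, the change in ring size and the added oxygen. Compound 4 also stands close to the end of the range the assay reports: the limit of > 10000 nM in this assay, at which 1 of the 4 values shown sits.

From the compounds shown here alone, whether a plain phenyl or a thiophene ring at this place would stay closer to compound 2 remains open. So does whether a pyridine ring would follow furan-2-yl or 4-chlorophenyl.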